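Replacing an Isopropyl Group with a Chlorinated Phenyl Ring

The source may hold more compounds than are shown below. What is called first, only, known or untested is meant among the compounds shown, and "the series" means these compounds.

Compound 2 `CC(C)c1cc2oc(N3CCC(C(=O)N[C@H]4CCC[C@H](CO)C4)CC3)nc2cc1Cl` is measured in an ADME assay on microsomes from liver (Homo sapiens) for metabolic stability (on this read-out lower numbers stand for slow clearance and higher numbers for fast clearance), where compound 2 gives 46.4 mL/min/kg. Among the numbers shown, this is the lowest of the two plain values, with compound 1 `CCc1cc2oc(N3CCC(C(=O)N[C@H]4CCC[C@H](CO)C4)CC3)nc2cc1Cl` nearest: in this assay compound 1 gives 64.6 mL/min/kg, and the change a 1.4-fold lower number from compound 1 to compound 2 (0.14 log units; within the scatter) stays within the scatter. Compound 3 `N#Cc1ccc2oc(N3CCC(C(=O)N[C@H]4CCC[C@H](CO)C4)CC3)nc2c1` gives only a limit in this assay, < 8 mL/min/kg, so its value is a boundary and not a number, which is the limit of < 8 mL/min/kg in this assay, at which 1 of the 3 values shown sits.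

Compound 4 `O=C(N[C@H]1CCC[C@H](CO)C1)C1CCN(c2nc3cc(Cl)c(-c4cccc(Cl)c4)cc3o2)CC1` differs from compound 2 in one place: 3-chlorophenyl in place of isopropyl on an aromatic carbon. Going by the values given here, the single measured step, from compound 1 to compound 2, swaps one saturated group for another and was within the scatter, so it offers no direct guide to exchanging a saturated group for an aromatic ring. Among the compounds with values here, with no measured step bearing on such a change, no move beyond the scatter in this assay is expected, and the step of a 1.2-fold lower number from compound 2 to compound 4 (0.06 log units; within the scatter) is estimated near no change. Compound 4 is therefore expected to give about 40 mL/min/kg, within a range from 15 mL/min/kg to 90 mL/min/kg.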

Compound 4, clearance: 55.8 mL/min/kg
Compound 4: middle estimate off by 1.4-fold (0.14 log units), on the low side; low and high end bracket the measured number.
By their numbers in this assay, from the lowest: compounds 2, 4 and 1 (each within the scatter of the next). At a limit, below all of these: compound 3.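

On this aromatic carbon, ortho to a chloro group, the saturated chains can give way to a six-membered aromatic ring with no change beyond the scatter in this assay: the swap from isopropyl to 3-chlorophenyl gives a 1.2-fold higher number from compound 2 to compound 4 (0.08 log units; within the scatter), and the swap from ethyl to 3-chlorophenyl gives a 1.2-fold lower number from compound 1 to compound 4 (0.06 log units; within the scatter). Going by these compounds alone, the earlier step exchanged only one saturated group for another, whereas these two steps show that adding a ring and a chlorine also leaves the read-out within the scatter at this position. No measurement shown here accounts for this absence of a clear change.

Going by these compounds, it remains open whether an amine, a carboxylic acid or a morpholine ring on this aromatic carbon would move the number beyond the scatter. A plain phenyl ring would show whether the chlorine on the added ring matters.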